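Swapping One Aryl Group on a Shared Core

The compounds below may be only part of what the source reports. "The series", "measured", "known", "first", "only" and "open" are said of these compounds alone.

Compound 1, `O=C(O)c1cc(F)c2nc(N3CCC4(C=C(c5c(-c6ccccc6C(F)(F)F)noc5C5CC5)C4)CC3)sc2c1`: 13.8 nM
Compound 2, `O=C(O)c1cc(F)c2nc(N3CCC(CCc4c(-c5c(Cl)cccc5Cl)noc4C4CC4)CC3)sc2c1`: 21.4 nM
Compound 3, `O=C(O)c1cc(F)c2nc(N3CC4C(/C=C/c5c(-c6c(Cl)cccc6Cl)noc5C5CC5)C4C3)sc2c1`: 120 nM

In an assay on HEK293 cells for agonist activity at Bile acid receptor (Homo sapiens), read by a luciferase reporter (a lower number here means that less compound is needed, a higher number that more compound is needed for the effect), compound 1 gives 13.8 nM, the lowest of the three numbers. Compound 2 sits within the scatter of compound 1, while compound 3 lies beyond the scatter at a higher number. Compound 4, `O=C(O)c1cc(F)c2nc(N3CCC4(C=C(c5c(-c6c(Cl)cncc6Cl)noc5C5CC5)C4)CC3)sc2c1`, has not yet been measured. It differs from compound 1 in one place: 3,5-dichloropyridin-4-yl in place of 2-(trifluoromethyl)phenyl on an aromatic carbon. For the measured compounds named here, no step between measured compounds isolates such a change, and compound 2 and compound 3 differ from compound 1 in more than one place, so the expectation rests on compound 1 alone. Compound 4 is expected to stay close to compound 1, with the step of a 1.4-fold higher number from compound 1 to compound 4 (0.16 log units; within the scatter) expected to fall within the scatter or slightly toward a higher number. The estimate for compound 4 is 20 nM, ranging from 7 nM to 60 nM.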

Compound 4, half-maximal effective concentration: 24.6 nM
Compound 4: middle estimate off by 1.2-fold (0.09 log units), on the low side; the measured number falls inside the stated range.
By their numbers in this assay, from the lowest: compounds 1, 2 and 4 (each within the scatter of the next); then compound 3.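

In this assay, putting 3,5-dichloropyridin-4-yl in place of 2-(trifluoromethyl)phenyl gives a 1.8-fold higher number from compound 1 to compound 4 (0.25 log units; within the scatter) on an otherwise unchanged structure. For the compounds shown here, this is the first step to isolate a change at this aromatic carbon, and it shows that this exchange of one aryl group for another stays within the scatter. Nothing available explains why the two groups read alike.

The compounds shown leave open how a saturated ring such as cyclohexyl, or a group as small as methyl, would read at this carbon. They also leave open how 2,6-dichlorophenyl, carried by compound 2 and compound 3, would read on the core of compound 1.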